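Swapping a chloropyridine amide for a chlorophenyl amide

This account rests on a few compounds, and the source may have more. Where it says the series, first, only, none or still open, it means among the compounds named here.

Compound 1 `O=C(Nc1ccc(Cl)c(-c2nnc3c(Cl)cccn23)c1)c1cccnc1` gives > 100000 nM in a functional assay on MCF7 cells (Homo sapiens) for antiproliferative activity, read by MTT assay, with a stated time of 72 h (a lower number here means a stronger inhibitor, a higher number a weaker inhibitor), which is a limit of the assay and not a number.
Compound 2 `O=C(Nc1ccc(Cl)c(-c2nnc3c(Cl)cccn23)c1)c1c(F)cccc1Cl` gives > 100000 nM in this assay, also a limit.
Compound 3 `O=C(Nc1ccc(Cl)c(-c2nnc3c(Cl)cccn23)c1)c1cccnc1Cl` gives > 100000 nM in this assay, also a limit.

All three share one core and differ only in the group attached to the carbonyl carbon of the amide. Compound 3 therefore stands where every measured compound stands: at the limit of > 100000 nM in this assay, at which 3 of the 3 values shown sit, with no number to place it against the others. The steps between them, a step that the two limits leave unreadable from compound 1 to compound 2, a step that the two limits leave unreadable from compound 1 to compound 3 and a step that the two limits leave unreadable from compound 2 to compound 3, cannot be sized, since both ends of each are limits.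

Compound 4 `O=C(Nc1ccc(Cl)c(-c2nnc3c(Cl)cccn23)c1)c1ccccc1Cl` is not yet measured. It differs from compound 3 by 2-chlorophenyl in place of 2-chloropyridin-3-yl on a carbonyl carbon. Every step measured so far on this core bears on this change, yet none is readable, so nothing shown points to a gain or loss beyond the scatter. Compound 4 is therefore expected to sit at the same limit, with a number no higher from compound 3 to compound 4 (the limit leaves the size open), and an estimated value of 100000 nM (range 30000 nM to 300000 nM).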

Compound 4, half-maximal inhibitory concentration: 92200 nM
Beside the measured number, compound 4's estimate is 1.1-fold (0.04 log units) above it; low and high end bracket the measured number.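

Compound 4 is the only compound on this core with a number rather than a limit of the assay in this assay, so this position can now give a value, however weak, while the others stay at the limit: the limit of > 100000 nM in this assay, at which 3 of the 4 values shown sit.
Replacing the ring nitrogen of the 2-chloropyridin-3-yl group gives an at least 1.0-fold lower number from compound 3 to compound 4 (0.03 log units; that floor lies within the scatter), removing the fluoro gives an at least 1.0-fold lower number from compound 2 to compound 4 (0.03 log units; that floor lies within the scatter), and the full change of group gives an at least 1.0-fold lower number from compound 1 to compound 4 (0.03 log units; that floor lies within the scatter). Each of these floors lies within the scatter, and the steps among compound 1, compound 2 and compound 3 cannot be read, so no real gain is shown.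

Going by these compounds, the true size of each new step remains open, as one end of each is a limit. The compounds shown also leave open whether a 2-methoxyphenyl or 2-aminophenyl group on the carbonyl carbon would give a clearly lower number.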